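Exchanging the anilino aryl group on the shared core

The compounds below may be only part of what the source reports. "The series", "measured", "known", "first", "only" and "open" are said of these compounds alone.

For the measured compounds named here, in a functional assay on ECa-109 cells (Homo sapiens) for cytotoxicity, read by MTT assay, with a stated time of 72 h (a lower number here means a stronger inhibitor, a higher number a weaker inhibitor), compound 2 `COc1ccccc1Nc1cc(C)nc(SCc2nc3ccccc3[nH]2)n1` gives 34400 nM, the only definite number so far. Compound 1 `Cc1cc(NNC(N)=S)nc(SCc2nc3ccccc3[nH]2)n1` reaches only the assay limit > 100000 nM in this assay, a case of the limit of > 100000 nM in this assay, at which 1 of the 2 values shown sits. Going by the values given here, the single measured step, an at least 2.9-fold lower number from compound 1 to compound 2 (0.46 log units; beyond the scatter), exchanges a thiourea-bearing chain for an aryl group and says nothing about trading one aryl group for another. Compound 3 `Cc1ccc(Nc2cc(C)nc(SCc3nc4ccccc4[nH]3)n2)cc1` carries 4-methylphenyl in place of 2-methoxyphenyl on a nitrogen on an aromatic ring. Among the compounds with values here, with no comparable step measured, no change beyond the scatter is expected. Compound 3 is therefore estimated at 30000 nM in this assay, with a range from 10000 nM to 100000 nM. That expectation corresponds to a 1.1-fold lower number from compound 2 to compound 3 (0.06 log units; within the scatter).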

Compound 3, half-maximal inhibitory concentration: 57300 nM
Estimate against measurement, compound 3: 1.9-fold (0.28 log units) below, and the stated range covers the measured number.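

In this assay, 4-methylphenyl in place of 2-methoxyphenyl on a nitrogen on an aromatic ring gives a 1.7-fold higher number from compound 2 to compound 3 (0.22 log units; within the scatter), so the one aryl-for-aryl exchange shown stays within the scatter. Set against the thiourea-bearing chain, the second aryl group gives only an at least 1.7-fold lower number from compound 1 to compound 3 (0.24 log units; that floor lies within the scatter), a floor that cannot show a real gain. The value of compound 1 is a limit of the assay and not a number: the limit of > 100000 nM in this assay, at which 1 of the 3 values shown sits.

The compounds shown leave open whether a phenyl ring carrying a carboxylic acid or an amine would move the number beyond the scatter. They also leave open whether a saturated ring such as cyclohexyl on this nitrogen would do so.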